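The source may report more compounds than this note shows. Statements on the series, on what has been measured and on what is new or still open speak of the compounds shown alone.

In a functional assay on FM3A cells (Mus musculus) for cytotoxicity (on this read-out lower numbers stand for an effect already at smaller amounts and higher numbers for an effect only at larger amounts of compound), compound 1 (`CCOOC1(OOCC)CCCCCCCCCCC1`) gives 10000 nM and stands second highest of three numbers. Compound 2 (`C=C(C)COOC1(OOCC(=C)C)CCCCCCCCCCC1`) gives 38000 nM on the higher side and compound 3 (`COOC1(OOCCCCCCO)CCCCCCCCCCC1`) gives 1600 nM on the lower side, both beyond the scatter from compound 1. Compound 4 (`CCOOC1(OC)CCCCCCCCCCC1`) is not yet measured and carries methyl in place of ethoxy on an oxygen on a saturated carbon relative to compound 1. Among the measured compounds shown here, no measured pair shows this change, so the expectation in this assay has little support: no step beyond the scatter, with a slight lean toward a higher number. The estimated step (a 1.4-fold higher number from compound 1 to compound 4 (0.15 log units; within the scatter)) stays small. For compound 4 the estimated value is 14000 nM with an expected range from 4000 nM to 50000 nM in this series.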

Compound 4, half-maximal effective concentration: 26000 nM
For compound 4 the middle estimate is 1.9-fold (0.27 log units) below the measured one, within the range that was stated.
By their numbers in this assay, from the lowest: compound 3; then compound 1; then compounds 4 and 2 (each within the scatter of the next).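

Methyl in place of ethoxy on an oxygen on a saturated carbon gives a 2.6-fold higher number from compound 1 to compound 4 (0.41 log units; beyond the scatter) in this assay and is the first single-place change readable in the series. The step is modest but beyond the scatter, so this position is not silent on the read-out. Nothing at hand explains the direction of the step.

A single pair cannot separate the loss of the ethoxy oxygen from the loss of its carbons. Going by these compounds, how an amine or a carboxylic acid on a longer chain would read at this position remains open.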